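This account rests on a few compounds, and the source may have more. Where it says the series, first, only, none or still open, it means among the compounds named here.

In a functional assay on HT-29 cells (Homo sapiens) for cytotoxicity, read by MTT assay, with a stated time of 72 h (a lower number here means a stronger inhibitor of growth, a higher number a weaker inhibitor of growth), the three measured compounds gave the following numbers:

compound 1, `CC(C)COC(=O)Nc1ccc([Se][Se]c2ccc(NC(=O)OCC(C)C)cc2)cc1`: 48600 nM
compound 2, `N#C[Se]c1ccc(NC(=O)Oc2ccc(F)cc2)cc1`: 37600 nM
compound 3, `C=CCOC(=O)Nc1ccc([Se]C#N)cc1`: 48600 nM

At the digits shown, compound 3 stands level with compound 1, and the number for compound 2 differs from both only within the scatter, so the three cannot be placed in any order. Compound 4 is `CCCOC(=O)Nc1ccc([Se]C#N)cc1`, not yet measured in this assay. It differs from compound 3 in one place: ethyl in place of vinyl on a saturated chain carbon bound to an oxygen next to a carbonyl group. Among the measured compounds shown here, no step between two measured compounds touches this kind of change, so the data offer no ground for a shift in either direction. The estimate for compound 4 therefore means a step of a 1.0-fold lower number from compound 3 to compound 4 (0.01 log units; within the scatter), expected to stay within the scatter. Compound 4 is estimated at 48000 nM, with a range from 20000 nM to 110000 nM.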

Compound 4, concentration for total growth inhibition: 51900 nM
Compound 4: middle estimate off by 1.1-fold (0.03 log units), on the low side, and the stated range covers the measured number.
By their numbers in this assay, from the lowest: compounds 2, 1, 3 and 4 (each within the scatter of the next).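

In this assay, ethyl in place of vinyl on a saturated chain carbon bound to an oxygen next to a carbonyl group gives a 1.1-fold higher number from compound 3 to compound 4 (0.03 log units; within the scatter). Among the compounds shown here, this is the first step at this place, and it shows that allyl and propyl cannot be told apart here, with or without the double bond outside aromatic rings. Nothing measured here bears on why the two groups read alike. Still open, on these data alone, is whether a longer chain, an amine or a carboxylic acid at this place would give a number beyond the scatter.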